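A few compounds are considered here, and "the series" means these few. Any claim that something is new, unique, unknown or untested is made for them only; others in the source may bear on it.

Compound 1 `COc1ccc(-n2cc(-c3ccc(OC)c(O)c3)nn2)cc1` and compound 2 `COc1ccc(-n2cc(-c3ccc(OC)c(O)c3)nn2)c(OC)c1` were both tested in a functional assay on MDA-MB-231 cells (Homo sapiens) for cytotoxicity, read by MTT assay; on this read-out lower numbers stand for stronger inhibition and higher numbers for weaker inhibition. In this assay compound 1 gives only a limit, > 10000 nM. Compound 2 also gives only a limit, > 10000 nM. The change between them, (hydrogen in place of methoxy on an aromatic carbon), made a step that the two limits leave unreadable from compound 2 to compound 1. Among the measured compounds shown here, compound 3 `COc1cc(-c2cn(-c3ccc(Oc4ccccc4)cc3)nn2)cc(OC)c1OC` carries a core whose difference from compound 2 is not broken down here; in this assay compound 3 gives 10000 nM, the only plain number among the three, the other two resting at the limit of > 10000 nM in this assay, at which 2 of the 3 values shown sit.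

Compound 4 `COc1ccc(-c2cn(-c3ccc(Oc4ccccc4)cc3)nn2)cc1OC` has not yet been measured. It differs from compound 3 by hydrogen in place of methoxy on an aromatic carbon. This is the same kind of change as from compound 2 to compound 1, though the surroundings differ: in compound 3 the leaving methoxy sits ortho to a methoxy group, meta to a large group and meta to a methoxy group, whereas in compound 2 it sits ortho to a large group and meta to a methoxy group. For the measured compounds named here, because the one comparison of this kind gave a step that the two limits leave unreadable from compound 2 to compound 1, little guidance on direction is available. The step expected is a 1.2-fold higher number from compound 3 to compound 4 (0.08 log units; within the scatter). Compound 4 is expected to give 12000 nM. Compound 4 is expected to fall between 4000 nM and 30000 nM, resting on compound 3 giving 10000 nM.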

Compound 4, half-maximal inhibitory concentration: 10000 nM
Compound 4: the middle estimate sits 1.2-fold (0.08 log units) above what was measured; the measured number falls inside the stated range.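

In this assay, hydrogen in place of methoxy on an aromatic carbon made no change at the digits printed from compound 3 to compound 4 (within the scatter). On the core of compound 3, then, this one methoxy group, ortho to a methoxy group, can be replaced by hydrogen without a readable shift in the number, though a single pair says nothing about other positions on that ring. Among the compounds shown here, it does not show that the change behaves the same way on another core, because the only other pair with this change, compound 2 and compound 1, cannot be read, with a limit on both sides: the limit of > 10000 nM in this assay, at which 2 of the 4 values shown sit.

Still open, as far as these compounds go, is whether a different group at this place on compound 4, such as an amine or a carboxylic acid, would move the number beyond the scatter. Also open, from the compounds shown here alone, is whether a longer chain there, in place of the methoxy group, would do so.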